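This account rests on a few compounds, and the source may have more. Where it says the series, first, only, none or still open, it means among the compounds named here.

Measured compounds:
- compound 1, `O=C1CC(C(F)(F)F)CN1c1cnn2c1CN(C(=O)Nc1cc(F)c(F)c(F)c1)C(C1CC1)C2`: 115000 nM
- compound 2, `C[C@H]1Cn2ncc(N3CC(c4ccccc4)CC3=O)c2CN1CC(=O)Nc1cc(F)c(F)c(F)c1`: > 2000 nM
- compound 3, `C[C@H]1Cn2ncc(N3CC(c4ccccc4)CC3=O)c2CN1C(=O)Nc1cc(F)c(F)c(F)c1`: 12800 nM

Three compounds of this series carry a value in a toxicity assay on HepG2 2.2.15 cells (Homo sapiens) for cytotoxicity, read by CellTiter-Glo; a higher number here means that more compound is tolerated, a lower number that less compound is tolerated. Compound 1 gives 115000 nM, the highest of the two numbers recorded. Compound 3 gives 12800 nM, a lower number and a gap from compound 1 that lies beyond the scatter. For compound 2 the read-out is a limit of the assay and not a number, > 2000 nM; (the limit of > 2000 nM in this assay, at which 1 of the 3 values shown sits). No pair among these three differs in a single place, so no step between measured compounds can be set down.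

Compound 4, `Cc1nc(C2CC(=O)N(c3cnn4c3CN(C(=O)Nc3cc(F)c(F)c(F)c3)C(C3CC3)C4)C2)no1`, is not yet measured in this assay. It differs from compound 1 in one place: 5-methyl-1,2,4-oxadiazol-3-yl in place of trifluoromethyl on a saturated ring carbon. The compound keeps the cyclopropyl-bearing core of compound 1 and the same urea to the trifluorophenyl group; only the substituent on the saturated ring carbon of the five-membered non-aromatic ring changes.

For the measured compounds named here, no measured step bears on that exchange, so nothing here points in a direction. The expectation for compound 4 is a step of a 1.2-fold lower number from compound 1 to compound 4 (0.06 log units; within the scatter), none beyond the scatter. Compound 4 is thus estimated at 100000 nM, with a range from 40000 nM to 200000 nM.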

Compound 4, half-maximal cytotoxic concentration: > 200000 nM
Compound 4: only a limit was reported; the forecaster's own chance of this, stated with the estimate: 15%; at least 2.0-fold (0.30 log units) between middle value and limit.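

For the compounds shown here, this is the only step at this position, a saturated ring carbon of the five-membered non-aromatic ring, as no earlier pair of compounds differed in a single place. In this assay, exchanging trifluoromethyl for 5-methyl-1,2,4-oxadiazol-3-yl gives an at least 1.7-fold higher number from compound 1 to compound 4 (0.24 log units; that floor lies within the scatter), so placing a five-membered aromatic ring with 3 hetero atoms on this carbon produces no drop in the number, although the floor of the step does not establish a rise beyond the scatter. Compound 4 carries a limit of the assay and not a number: the limit of > 200000 nM in this assay, at which 1 of the 4 values shown sits.

The compounds shown leave open how far the step extends past its floor, and compound 2 and compound 3, which carry phenyl on the same ring carbon, differ from compound 4 in more than one place and so give no step at this position. Also open, on these data alone, is how the number would respond on the core of compound 1 to a dimethylamino group, a carboxylic acid or a longer alkyl chain on this carbon.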